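A few compounds are considered here, and "the series" means these few. Any claim that something is new, unique, unknown or untested is made for them only; others in the source may bear on it.

Two compounds from this series have been examined in an ADME assay on BEAS-2B cells (Homo sapiens) for cytotoxicity, read by fluorescence, with a stated time of 48 h; a higher number here means that more compound is tolerated, a lower number that less compound is tolerated. Compound 1 `Cc1coc(C(=O)N2CCCn3nc(C(=O)Nc4ccccc4)cc3C2)c1C` gives 30000 nM in this assay. Compound 2 `Cc1ccoc1C(=O)N1CCCn2nc(C(=O)NCc3ccccc3)cc2C1` gives 50000 nM in this assay, which is the higher of the two numbers, though the gap to compound 1 lies within the usual scatter of such measurements, so the two compounds cannot be separated on this evidence.

Compound 3 `Cc1ccoc1C(=O)N1CCCn2nc(C(=O)Nc3ccncn3)cc2C1` has not yet been measured. It differs from compound 2 in a single place: pyrimidin-4-yl in place of benzyl on an amide-type nitrogen. Within the data shown here, no pair of measured compounds sharing exactly this difference is available, so the size of the step cannot be read from the numbers at hand; the only guide is that both measured compounds sit close together.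

Given that, compound 3 is expected to stay near where compound 2 stands, with a step of a 1.3-fold lower number from compound 2 to compound 3 (0.10 log units; within the scatter) that is not expected to go beyond the scatter in either direction. For compound 3 the estimated value in this assay is 40000 nM, with a range from 15000 nM to 100000 nM.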

Compound 3, half-maximal cytotoxic concentration: 16600 nM
For compound 3 the middle estimate is 2.4-fold (0.38 log units) above the measured one, and the stated range covers the measured number.
By their numbers in this assay, from the lowest: compounds 3, 1 and 2 (each within the scatter of the next, the first and the last beyond it).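

In this assay, among these compounds, the replacement of benzyl by pyrimidin-4-yl on the amide-type nitrogen brings a 3.0-fold lower number from compound 2 to compound 3 (0.48 log units; beyond the scatter) and gives the first single-place change in these compounds with a readable size. The step is modest, but it shows that the group on this nitrogen can shift the number beyond the scatter, here towards less compound being tolerated on the otherwise unchanged core of compound 2. Nothing at hand accounts for the step, which replaces a carbon-only ring with one holding two hetero atoms and also changes the group from benzyl to a directly attached ring.

The compounds shown leave open which part of this double change matters, a question that a pyrimidin-4-ylmethyl group or a pyridin-4-yl group on the same nitrogen would help to separate. They also leave open how far the number moves with groups of another kind there, such as a 2-(dimethylamino)ethyl chain or a cyclohexyl ring, and whether the same exchange gives a similar step on a different acyl group.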